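Aminophenyl to Difluorophenyl on a Pyrazole Chalcone Scaffold

A few compounds are considered here, and "the series" means these few. Any claim that something is new, unique, unknown or untested is made for them only; others in the source may bear on it.

Measured compounds:
Compound 1, `COc1ccc(-c2cc(/C=C/C(=O)c3ccc(N)cc3)[nH]n2)cc1`, gives 93%.
Compound 2, `COc1cc(-c2cc(/C=C/C(=O)c3ccc(N)cc3)[nH]n2)cc(OC)c1OC`, gives 98%.

Both numbers come from a functional assay on SN12C cells (Homo sapiens) for cytotoxicity, read by sulforhodamine B assay, with a stated time of 48 h, tested at 0.01 uM; on this read-out lower numbers stand for a stronger effect and higher numbers for a weaker effect at the one concentration tested. Compound 2 and compound 1 share the same core and differ only in the methoxy pattern on one aromatic ring; their values in this assay lie within the scatter of each other, so neither can be called more or less active than the other. Both sit close to full activity, which on this read-out means the cells were barely affected at the single concentration used.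

Compound 3, `COc1cc(-c2cc(/C=C/C(=O)c3ccc(F)c(F)c3)[nH]n2)cc(OC)c1OC`, has not yet been measured. It keeps the core of compound 2 and changes one group: 3,4-difluorophenyl in place of 4-aminophenyl on a carbonyl carbon. Going by the values given here, no measured pair shows what such a swap does in this assay, so the expectation rests only on the two values given. With both measured compounds close to full activity, the step expected is a number 3 percentage points lower from compound 2 to compound 3 (within the scatter), none beyond the scatter. For compound 3 the estimated value is 95%, with a range from 82% to 105%.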

Compound 3, a percentage reported as activity, at one concentration (the size of the read-out at that concentration, not a potency): 95%
Compound 3: the middle estimate sits on the measured number at the digits printed; the measured number falls inside the stated range.
By their numbers in this assay, from the lowest: compounds 1, 3 and 2 (each within the scatter of the next).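

In this assay the swap to 3,4-difluorophenyl in place of 4-aminophenyl on a carbonyl carbon gives a number 3 percentage points lower from compound 2 to compound 3 (within the scatter) and so the two groups cannot be told apart here. Going by these compounds alone, this is the first view of this position, as the earlier pair differed only in the methoxy pattern on another ring, and it shows that replacing a group that has a hydrogen-bond donor and acceptor with one that has neither leaves no readable mark at this single concentration. That is weak evidence that the position does not matter, since the cells were barely affected by either compound, and nothing on hand offers an explanation for the result.

A concentration at which the cells are clearly affected would be needed to show whether these two groups truly behave alike. Going by these compounds, it also remains open whether a quite different group on the same carbonyl carbon, such as a phenyl ring carrying a carboxylic acid or a longer alkyl chain in place of the ring, would move the read-out beyond the usual scatter.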